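The source may report more compounds than this note shows. Statements on the series, on what has been measured and on what is new or still open speak of the compounds shown alone.

Compound 1 `Cc1ccccc1S(=O)(=O)N1C(=O)COC12C=CC(=O)C=C2`: > 10000 nM
Compound 2 `O=C1C=CC2(C=C1)OCC(=O)N2S(=O)(=O)c1ccc(Cl)cc1`: 2800 nM

Within the data shown here, in a functional assay on MDA-MB-231 cells (Homo sapiens) for inhibition, read by sulforhodamine B assay, with a stated time of 74 h (on this read-out higher numbers stand for weaker inhibition and lower numbers for stronger inhibition), compound 2 gives 2800 nM, the only actual number so far. Compound 1 reads > 10000 nM, which is a limit of the assay. Among the measured compounds shown here, the single measured step, an at least 3.5-fold lower number from compound 1 to compound 2 (0.55 log units; beyond the scatter), lies beyond the scatter and swaps 4-chlorophenyl for 2-methylphenyl on a sulfonyl sulfur, so it touches the same aromatic group. Compound 3 `O=C1C=CC2(C=C1)OCC(=O)N2S(=O)(=O)c1ccc(N2CCCC2=O)cc1` differs from compound 2 by 2-oxopyrrolidin-1-yl in place of chloro on an aromatic carbon, with 2-oxopyrrolidin-1-yl in place of chloro. That one step shows this group can matter but gives no direction for the new change, so no shift beyond the scatter is expected in this assay. The expected change is a 1.1-fold higher number from compound 2 to compound 3 (0.03 log units; within the scatter). Compound 3 is estimated at 3000 nM, with an expected range of 800 nM to 10000 nM.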

Compound 3, half-maximal inhibitory concentration: > 10000 nM
Compound 3 ended at the assay's limit (the forecaster's own chance of this, stated with the estimate: 20%); middle value at least 3.3-fold (0.52 log units) from the limit.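

In this assay, 2-oxopyrrolidin-1-yl in place of chloro on an aromatic carbon gives an at least 3.5-fold higher number from compound 2 to compound 3 (0.55 log units; beyond the scatter), so this position does not accept every group without a change beyond the scatter. Compound 3 reads > 10000 nM, which is a limit and not a number, so the step has a lower bound but no known size. Only compound 2 therefore gives an actual number here, and the rest cannot be ranked: the limit of > 10000 nM in this assay, at which 2 of the 3 values shown sit.

As far as these compounds go, whether fluoro or methoxy at this carbon would read lower than compound 2 stays open. So does whether an open-chain amide or an amine would behave like 2-oxopyrrolidin-1-yl.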